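Trimethoxyphenyl amide in the indolyl-thiazole series

The source may hold more compounds than are shown below. What is called first, only, known or untested is meant among the compounds shown, and "the series" means these compounds.

Measured so far in a functional assay on MDA-MB-231 cells (Homo sapiens) for cytotoxicity, read by MTT assay, with a stated time of 48 h, in the absence of a further agent; a lower number here means a stronger inhibitor, a higher number a weaker inhibitor:
compound 1, `COc1ccc(NC(=O)c2csc(-c3cn(Cc4ccc(Cl)cc4)c4ccccc34)n2)cc1`, gives 84900 nM
compound 2, `O=C(Nc1ccccc1)c1csc(-c2cn(Cc3ccc(Cl)cc3)c3ccccc23)n1`, gives 50500 nM
compound 3, `O=C(Nc1ccccc1)c1csc(-c2c[nH]c3ccccc23)n1`, gives 79400 nM

Compound 2 shows the lowest number of the three, but its separation from the others is slight: the step of a 1.7-fold lower number from compound 1 to compound 2 (0.23 log units; within the scatter) and the step of a 1.6-fold higher number from compound 2 to compound 3 (0.20 log units; within the scatter) both fall within the scatter, so the three measured compounds cannot be ordered against one another.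

Compound 4, `COc1cc(NC(=O)c2csc(-c3cn(Cc4ccc(Cl)cc4)c4ccccc34)n2)cc(OC)c1OC`, is the next compound to read in this assay. It differs from compound 2 in one place: 3,4,5-trimethoxyphenyl in place of phenyl on an amide-type nitrogen. For the measured compounds named here, the one measured step that touches the same ring is the step from compound 1 to compound 2, where a methoxy on that aryl ring was exchanged for hydrogen; that step was a 1.7-fold lower number from compound 1 to compound 2 (0.23 log units; within the scatter), within the scatter. Going by the values given here, the move to compound 4 places three methoxy groups on the same ring, which goes beyond what the single methoxy of compound 1 tested, so the measured steps give no ground to expect a shift beyond the scatter in either direction.

Compound 4 is therefore expected to give about 60000 nM in this assay, within a range of 20000 nM to 180000 nM, which means an expected step of a 1.2-fold higher number from compound 2 to compound 4 (0.07 log units; within the scatter).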

Compound 4, half-maximal inhibitory concentration: > 100000 nM
Compound 4 gave a limit, no number (the forecaster's own chance of this, stated with the estimate: 15%); middle value at least 1.6-fold (0.22 log units) from the limit.
By their numbers in this assay, from the lowest: compounds 2, 3 and 1 (each within the scatter of the next). At a limit, above all of these: compound 4.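

Compound 4 carries a limit, not a number, in this assay: the limit of > 100000 nM in this assay, at which 1 of the 4 values shown sits.

For the compounds shown here, on the amide-type nitrogen, the change from phenyl to 3,4,5-trimethoxyphenyl gives a step that is only a floor, an at least 1.9-fold higher number from compound 2 to compound 4 (0.29 log units; that floor lies within the scatter), and the change from the single methoxy of compound 1 gives another floor, an at least 1.1-fold higher number from compound 1 to compound 4 (0.07 log units; that floor lies within the scatter); neither establishes a separation beyond the scatter, and the true size of either gap stays unknown. Going by these compounds alone, what compound 4 adds is a first reading on a ring with three methoxy groups at this position, and this substitution shows no move to a lower number than the unsubstituted phenyl of compound 2.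

Still open, going by these compounds, is whether any group on this nitrogen can separate from phenyl towards a lower number, for instance a ring carrying a primary amine or a carboxylic acid, or a pyridine ring in place of the phenyl. Also open, on these data alone, is whether 3,4,5-trimethoxyphenyl reads the same way with hydrogen in place of 4-chlorobenzyl on the aromatic nitrogen of the core.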